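Cytotoxicity of the alkoxy series: toward the allyloxy analogue

The source may report more compounds than this note shows. Statements on the series, on what has been measured and on what is new or still open speak of the compounds shown alone.

compound 1 `CCCOc1nc(N)nc2c1ncn2/C=C1/CC1(CO)CO` — > 20000 nM
compound 2 `CN(C)c1nc(N)nc2c1ncn2/C=C1/CC1(CO)CO` — > 20000 nM

In an ADME assay on BCBL1 cells (Homo sapiens) for cytotoxicity, with a stated time of 7 days (a higher number here means that more compound is tolerated, a lower number that less compound is tolerated), compound 1 stands at > 20000 nM, which is a limit of the assay and not a number. Compound 2 likewise sits at a limit, > 20000 nM. The step that the two limits leave unreadable from compound 1 to compound 2 cannot be sized due to the limit of > 20000 nM in this assay, at which 2 of the 2 values shown sit.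

Compound 3 `C=CCOc1nc(N)nc2c1ncn2/C=C1/CC1(CO)CO` differs from compound 1 by vinyl in place of ethyl on a saturated chain carbon bound to an oxygen on an aromatic ring. For the measured compounds named here, no measured step bears on this change, and the one step measured is unreadable, so no shift beyond the scatter is expected. The estimated step is a step that the limit leaves unreadable from compound 1 to compound 3. Compound 3 is therefore expected near 30000 nM, within 15000 nM to 100000 nM.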

Compound 3, half-maximal cytotoxic concentration: > 20000 nM
Compound 3 gave a limit, no number (the forecaster's own chance of this, stated with the estimate: 85%); the middle value lies beyond the limit too.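

No step among compound 1, compound 2 and compound 3 can be read, because all three sit at the same limit, not a number: the limit of > 20000 nM in this assay, at which 3 of the 3 values shown sit.

From the compounds shown here alone, whether the propoxy, allyloxy and dimethylamino compounds differ in tolerated concentration remains open.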